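Trading a methoxyphenyl for a difluorophenyl

This account rests on a few compounds, and the source may have more. Where it says the series, first, only, none or still open, it means among the compounds named here.

Measured so far:
compound 1 `COc1ccc(-c2cn(C/C=C3\OC(=O)C(OCc4ccccc4)=C3OCc3ccccc3)nn2)cc1` — in a functional assay on CFPAC-1 cells (Homo sapiens) for antiproliferative activity, read by MTT assay, with a stated time of 72 h (on this read-out lower numbers stand for stronger inhibition and higher numbers for weaker inhibition), compound 1 reaches only a limit, > 100000 nM.
compound 2 `Cc1ccc(S(=O)(=O)NCc2cn(C[C@H](O)[C@H]3OC(=O)C(OCc4ccccc4)=C3OCc3ccccc3)nn2)cc1` — in this assay compound 2 gives 68000 nM.

Compound 1 thus has no number of its own, only (the limit of > 100000 nM in this assay, at which 1 of the 2 values shown sits), and compound 2 is weak as well. Compound 3 `O=C1O/C(=C\Cn2cc(-c3cc(F)cc(F)c3)nn2)C(OCc2ccccc2)=C1OCc1ccccc1` differs from compound 1 by 3,5-difluorophenyl in place of 4-methoxyphenyl on an aromatic carbon. Going by the values given here, no measured step covers such a change, so the move from compound 1 to compound 3 is expected to stay within the scatter, a number no higher from compound 1 to compound 3 (the limit leaves the size open). Compound 3 is therefore estimated at 100000 nM, between 30000 nM and 300000 nM, and will most likely again be reported only as a limit.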

Compound 3, half-maximal inhibitory concentration: "not active" (no number reported)
Compound 3 has no reported number here, and the estimate cannot be compared.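

No step can be read between compound 1, which holds only a limit, and compound 3, which has no reported number. The compounds shown leave open whether 3,5-difluorophenyl in place of 4-methoxyphenyl changes anything in this assay.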